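This account rests on a few compounds, and the source may have more. Where it says the series, first, only, none or still open, it means among the compounds named here.

Compound 1 `Cc1ccc(CN2CCC(NC(=O)NCc3ccc(-c4ccc(F)cc4)cc3)CC2)cc1` is the stronger of the two compounds measured in an in vitro functional assay on HEK293 cells for antagonist activity at melanin-concentrating hormone receptor 1 (Homo sapiens), read by GTPgammaS binding, with a stated time of 45 min (a higher number here means a more potent compound, by a factor of ten per unit of this negative logarithm, a lower number a less potent compound), where compound 1 gives 6.71. Going by the values given here, its only measured neighbour, compound 2 `COc1ccccc1-c1ccc(CNC(=O)NC2CCN(Cc3ccc(C)cc3)CC2)cc1`, differs by carrying a 2-methoxyphenyl in place of the 4-fluorophenyl on an aromatic carbon, and in this assay compound 2 gives 6.19; that change costs a number 0.52 log units lower from compound 1 to compound 2 (beyond the scatter).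

Compound 3 `Cc1ccc(CN2CCC(NC(=O)N(CC(=O)C(C)(C)O)Cc3ccc(-c4ccc(F)cc4)cc3)CC2)cc1` keeps the 4-fluorophenyl of compound 1 and instead alters the urea: ((1-hydroxy-1-methylethyl)carbonyl)methyl in place of hydrogen on an amide-type nitrogen. Among the compounds with values here, no measured step touches this amide-type nitrogen; the single step on record, from compound 1 to compound 2, concerns the aromatic carbon and says nothing about substitution on the urea. The expectation therefore rests on the size of the incoming group alone, and a modest loss rather than a gain seems the more likely outcome, though a result within the scatter cannot be excluded. Compound 3 is accordingly expected to come in at 6.2, within a range of 5.4 to 7. This estimate amounts to an expected step of a number 0.51 log units lower from compound 1 to compound 3 (beyond the scatter).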

Compound 3, negative logarithm of the antagonist equilibrium constant: 5.34
For compound 3 the middle estimate is 0.86 log units above the measured one; measured number outside the range, below it.
By their numbers in this assay, from the lowest: compound 3; then compound 2; then compound 1.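

The amide-type nitrogen, which the earlier pair left untouched, now has a measured step: in this assay, ((1-hydroxy-1-methylethyl)carbonyl)methyl in place of hydrogen gives a number 1.37 log units lower from compound 1 to compound 3 (beyond the scatter), a large change. Going by these compounds alone, the only other change on record from compound 1 is the modest one at the aromatic carbon, a number 0.52 log units lower from compound 1 to compound 2 (beyond the scatter), so this nitrogen is the more sensitive of the two places examined so far, on the strength of one substituent at each. The loss is not total, since compound 3 still gives 5.34 as a measured number and so the urea nitrogen can carry this group of 7 heavy atoms with a numerical read-out retained. No evidence available here bears on why the step at this nitrogen is so large.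

With a single substituent at this nitrogen, the compounds leave open whether the loss follows from the whole group or from one part of it, such as its ketone carbonyl or its hydroxyl; a plain methyl or a 2-hydroxyethyl on the same nitrogen would help separate these. They also leave open whether the other urea nitrogen, the one attached to the saturated ring, responds to substitution in the same way.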